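Trifluoromethyl for Fluoro on the Pendant Phenyl

A few compounds are considered here, and "the series" means these few. Any claim that something is new, unique, unknown or untested is made for them only; others in the source may bear on it.

Compound 1 `O=C(Nc1ccc(Oc2ccnc3[nH]ccc23)cc1)c1nn(-c2ccc(Cl)cc2)ccc1=O` gives 32400 nM in a functional assay on PC-3 cells (Homo sapiens) for cytotoxicity, read by MTT assay, with a stated time of 72 h; a lower number here means a stronger inhibitor, a higher number a weaker inhibitor.
Compound 2 `Cc1cc(=O)n(-c2cccc(F)c2)nc1C(=O)Nc1ccc(Oc2ncnc3[nH]ccc23)cc1` gives 14600 nM in this assay.
Compound 3 `Cc1cc(=O)n(-c2cccc(F)c2)nc1C(=O)Nc1ccc(Oc2ncnc3[nH]ccc23)c(F)c1` gives 6680 nM in this assay.

Among these three, compound 3 carries the lowest number; compound 2 lies nearer to it and compound 1 furthest away. Going by the values given here, the one single-point step available is a 2.2-fold lower number from compound 2 to compound 3 (0.34 log units; beyond the scatter), which concerns a fluoro added on the central ring, not the pendant phenyl.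

Compound 4 `Cc1cc(=O)n(-c2cccc(C(F)(F)F)c2)nc1C(=O)Nc1ccc(Oc2ncnc3[nH]ccc23)c(F)c1` differs from compound 3 by trifluoromethyl in place of fluoro on an aromatic carbon, so 3-fluorophenyl becomes 3-(trifluoromethyl)phenyl. Among the compounds with values here, no measured step touches that position, so the three compounds give no direction for this change. Compound 4 is therefore expected to land close to compound 3, with an expected step of a 1.1-fold lower number from compound 3 to compound 4 (0.05 log units; within the scatter) in this assay that need not exceed the scatter. The estimate for compound 4 is 6000 nM, between 2000 nM and 20000 nM.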

Compound 4, half-maximal inhibitory concentration: 15600 nM
The estimate for compound 4 lay 2.6-fold (0.41 log units) below the measured number; measured number inside the range.
By their numbers in this assay, from the lowest: compound 3; then compounds 2 and 4 (each within the scatter of the next); then compound 1.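

Replacing fluoro with trifluoromethyl on the pendant phenyl gives a 2.3-fold higher number from compound 3 to compound 4 (0.37 log units; beyond the scatter) in this assay. The position is therefore not indifferent to its substituent, and this change weakens the compound. Nothing measured here explains why.

The compounds shown leave open how a methoxy group or an amine in this place would compare with fluoro. They also leave open whether the same swap would have a similar effect on compound 2, which lacks the fluoro added in compound 3.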